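A few compounds are considered here, and "the series" means these few. Any claim that something is new, unique, unknown or untested is made for them only; others in the source may bear on it.

Compound 1 `Cc1cccc(-c2nc(C)c(COc3ccc4c(c3)OCC4CC(=O)O)s2)c1` gives 119 nM in a functional assay on CHO cells for agonist activity at Free fatty acid receptor 1 (Homo sapiens), read by FLIPR and calcium flux; a higher number here means that more compound is needed for the effect, a lower number that less compound is needed. Compound 2 `Cc1nc(-c2ccccc2Cl)sc1COc1ccc2c(c1)OCC2CC(=O)O` has its result in this assay given as "not determined" (no result reported), so it stands on no number there, and compound 1 is the only measured point of reference. Compound 3 `Cc1nc(-c2ccc(Cl)cc2)sc1COc1ccc2c(c1)OCC2CC(=O)O` differs from compound 2 in one place: 4-chlorophenyl in place of 2-chlorophenyl on an aromatic carbon. Among the measured compounds shown here, no measured step exists between compound 2 and compound 3, so no direction or size can be drawn from data; the position of the chlorine on the phenyl may or may not matter beyond the scatter. Compound 3 is expected to give about 150 nM in this assay, within a range of 40 nM to 600 nM.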

Compound 3, half-maximal effective concentration: 85.6 nM
Beside the measured number, compound 3's estimate is 1.8-fold (0.24 log units) above it; measured number inside the range.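

On an aromatic carbon of the five-membered aromatic ring, 4-chlorophenyl in place of 3-methylphenyl gives a 1.4-fold lower number from compound 1 to compound 3 (0.14 log units; within the scatter) in this assay, so this exchange of one substituted phenyl for another is not told apart from repeat measurement. The step from compound 2 to compound 3 cannot be read, as compound 2 has no number. Nothing at hand offers an explanation for this result. From the compounds shown here alone, what 2-chlorophenyl does at this position remains open. So does whether a pyridyl ring or 4-methoxyphenyl there would shift the number beyond the scatter.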